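A few compounds are considered here, and "the series" means these few. Any claim that something is new, unique, unknown or untested is made for them only; others in the source may bear on it.

Measured compounds:
compound 1 `O=C(/C=C1\CCc2ccc(F)cc21)NCCO`, in a functional assay on the whole organism with Rattus norvegicus as the target, at a dose of 20 mg/kg by the oral route (on this read-out higher numbers stand for more inhibition at the one dose given (going by the name of the read-out) and lower numbers for less inhibition), compound 1 gives 42%
compound 2 `CCNC(=O)/C=C1\CCc2ccc(F)cc21`, in this assay compound 2 gives 45%

Compound 2 and compound 1 differ in one place, hydrogen in place of hydroxy on a saturated chain carbon, two bonds along the chain from an amide-type nitrogen, and the step of a number 3 percentage points higher from compound 1 to compound 2 (within the scatter) lies within the scatter, so the two numbers cannot be told apart; compound 2 stands level with compound 1 on what has been measured.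

The next compound, compound 3 `CC(C)NC(=O)/C=C1\CCc2ccc(F)cc21`, is not yet measured. It differs from compound 2 by methyl in place of hydrogen on a saturated chain carbon bound to an amide-type nitrogen and a saturated chain carbon. Going by the values given here, the only measured step, from compound 1 to compound 2, touched the same chain but with a different change, and it stayed within the scatter. Among the compounds with values here, no measured step shows a methyl entering on the chain carbon bound to the amide-type nitrogen, so there is no precedent for a shift in either direction. On this basis no step beyond the scatter is expected in this assay: the estimated step is no change at the digits printed from compound 2 to compound 3 (within the scatter). Compound 3 is therefore estimated at 45%, with a range from 30% to 60%.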

Compound 3, a percentage reported as inhibition, in the whole organism at one dose (the size of the read-out at that dose, not a potency): 45%
For compound 3 middle estimate and measured number coincide at the digits printed; low and high end bracket the measured number.
By their numbers in this assay, from the lowest: compounds 1, 2 and 3 (each within the scatter of the next).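

In this assay, going by these compounds alone, methyl in place of hydrogen on a saturated chain carbon bound to an amide-type nitrogen and a saturated chain carbon gives a first measured step at this position (no change at the digits printed from compound 2 to compound 3 (within the scatter)), and that step stays within the scatter. Replacing the whole group on the amide-type nitrogen, isopropyl in place of 2-hydroxyethyl, also stays within the scatter (a number 3 percentage points higher from compound 1 to compound 3 (within the scatter)), so ethyl, isopropyl and 2-hydroxyethyl on this nitrogen cannot be told apart on this read-out at the one dose given. Nothing available bears on why these numbers stand level.

The compounds shown leave open whether a longer chain such as n-butyl, a tert-butyl group, or a chain ending in an amine or a carboxylic acid on the amide-type nitrogen would give a step beyond the scatter. Also open, from the compounds shown here alone, is whether a change on the shared core, such as another group in place of the fluorine, would do so, and whether these readings would hold at any other dose.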